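A few compounds are considered here, and "the series" means these few. Any claim that something is new, unique, unknown or untested is made for them only; others in the source may bear on it.

Three measured compounds share one core and differ only in the aryl group on the aromatic nitrogen. Compound 1 `CC(C)(C)OC(=O)N1CCC(OC(=O)c2cn(-c3ccc(C(F)(F)F)cc3)nn2)CC1` gives 10.4 nM in an assay on HEK293 cells for agonist activity at Glucose-dependent insulinotropic receptor (Homo sapiens), read by a luciferase reporter, with a stated time of 24 h; on this read-out lower numbers stand for an effect already at smaller amounts and higher numbers for an effect only at larger amounts of compound; compound 2 `CC(C)(C)OC(=O)N1CCC(OC(=O)c2cn(-c3nc4ccccc4s3)nn2)CC1` gives 8.17 nM in this assay; compound 3 `CC(C)(C)OC(=O)N1CCC(OC(=O)c2cn(-c3ccc(C#N)cc3F)nn2)CC1` gives 3.59 nM in this assay. Compound 3 stands lowest of the three: a 2.9-fold lower number from compound 1 to compound 3 (0.46 log units; beyond the scatter) and a 2.3-fold lower number from compound 2 to compound 3 (0.36 log units; beyond the scatter), while a 1.3-fold lower number from compound 1 to compound 2 (0.10 log units; within the scatter).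

Compound 4 `CC(C)(C)OC(=O)N1CCC(OC(=O)c2cn(-c3ccc(S(C)(=O)=O)cc3F)nn2)CC1` keeps the ring of compound 3 and carries the change (methylsulfonyl in place of cyano on an aromatic carbon). Going by the values given here, no measured step exchanges one substituent on that ring; the two steps that reach compound 3 replace the whole aryl group and were modest in size, so they only show that changes in this part of the molecule have so far moved this assay by modest amounts. A step of similar or smaller size is expected here, in either direction, with a slightly higher number somewhat more likely; the estimate is a 1.7-fold higher number from compound 3 to compound 4 (0.22 log units; within the scatter). Compound 4 is therefore expected to give about 6 nM in this assay, within a range from 2 nM to 20 nM.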

Compound 4, half-maximal effective concentration: 14 nM
Estimate against measurement, compound 4: 2.3-fold (0.37 log units) below, and the stated range covers the measured number.
By their numbers in this assay, from the lowest: compound 3; then compounds 2, 1 and 4 (each within the scatter of the next).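

In this assay, exchanging cyano for methylsulfonyl on the aromatic carbon para to a large group gives a 3.9-fold higher number from compound 3 to compound 4 (0.59 log units; beyond the scatter), and this is the only step shown that alters a single substituent while the rest of the aryl group stays the same. It shows that this position is not indifferent: a substituent exchange alone, with the fluoro group kept, moves the number beyond the scatter and by a step also classed as modest, like those that replaced the whole aryl group. No evidence is available that explains the direction or size of this step.

Still open, as far as these compounds go, is how other groups at this position, such as a carboxamide, a methoxy group or a chlorine atom, would read in this assay. Also open, from the compounds shown here alone, is whether the same exchange gives a similar step on a ring without the fluoro group.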